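This account rests on a few compounds, and the source may have more. Where it says the series, first, only, none or still open, it means among the compounds named here.

Working notes on the series. Compound 1 `O=C(O)Cc1sc(C(c2ccccc2)c2ccc(Cl)cc2)nc1-c1ccc(Cl)cc1` and compound 2 `O=C(O)Cc1sc(C(c2ccc(F)cc2)c2ccc(F)cc2)nc1-c1cccc(F)c1` share the same core carrying a carboxymethyl group and two aryl substituents. In an in vitro assay on HEK385-7 cells for displacement of a labelled ligand from prostaglandin D2 receptor 2 (Homo sapiens) (on this read-out higher numbers stand for weaker inhibition and lower numbers for stronger inhibition), compound 1 gives 45 nM, while compound 2 gives 1.4 nM. Compound 2 therefore holds the lowest of the two numbers, and the gap to compound 1 lies well beyond the scatter.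

Compound 3 `NS(=O)(=O)c1ccc(-c2nc(C(c3ccc(F)cc3)c3ccc(F)cc3)sc2CC(=O)O)cc1` is not yet measured in this assay. It differs from compound 2 in one place: 4-sulfamoylphenyl in place of 3-fluorophenyl on an aromatic carbon. Among the compounds with values here, no measured pair covers this exchange, so the size of the step cannot be read from the data; a modest move toward a higher number is expected, estimated as a 2.9-fold higher number from compound 2 to compound 3 (0.46 log units; beyond the scatter), though a step within the scatter is also plausible. Compound 3 is expected to give about 4 nM in this assay, within a range from 0.8 nM to 25 nM.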

Compound 3, half-maximal inhibitory concentration: 1500 nM
Beside the measured number, compound 3's estimate is 380-fold (2.57 log units) below it; the measured number lies above the stated range.
By their numbers in this assay, from the lowest: compound 2; then compound 1; then compound 3.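

In this assay, the aromatic carbon next to the ring nitrogen and next to the ring atom that bears a carboxymethyl group proves highly sensitive to the aryl group it carries: 4-sulfamoylphenyl in place of 3-fluorophenyl gives a 1100-fold higher number from compound 2 to compound 3 (3.03 log units; beyond the scatter). Within the data shown here, compounds 1 and 2 differ in more than one place, so this is the first step that can be assigned to this position alone. No available evidence accounts for the size of this step.

The compounds shown leave open whether the step follows from the sulfamoyl group itself, from the loss of the fluorine, or from the different substitution on the phenyl ring. An unsubstituted phenyl, or a phenyl carrying a methylsulfonyl or carboxamide group, at this position would help separate these possibilities.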